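The compounds below may be only part of what the source reports. "The series", "measured", "known", "first", "only" and "open" are said of these compounds alone.

Compound 1 `COc1ccc(F)cc1CNCCCNc1ccnc2cc(Cc3ccccc3)ccc12`: 4200 nM
Compound 2 `COc1ccc(F)cc1CNCCCNc1ccnc2cc(-c3ccc(C(C)(C)C)cc3)ccc12`: 32000 nM
Compound 3 `COc1ccc(F)cc1CNCCCNc1ccnc2cc(-c3ccc(C(F)(F)F)cc3)ccc12`: 32000 nM

The three measured compounds share one core and differ only in the group carried on one aromatic carbon of that core. In a physicochemical assay for solubility, with a stated time of 18 h, at pH 7.4 (a higher number here means a more soluble compound, a lower number a less soluble compound), compound 1 gives 4200 nM. Compound 2 gives 32000 nM in this assay, and compound 3 gives 32000 nM. Compound 3 thus stands level with compound 2, the two together giving the highest of the three numbers, while compound 1 lies furthest away: a 7.6-fold higher number from compound 1 to compound 3 (0.88 log units; beyond the scatter). Between the two larger groups there is nothing to separate: no change at the digits printed from compound 2 to compound 3 (within the scatter).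

Compound 4 `COc1ccc(F)cc1CNCCCNc1ccnc2cc(Oc3ccccc3OC)ccc12` is not yet measured. It differs from compound 3 in one place: 2-methoxyphenoxy in place of 4-(trifluoromethyl)phenyl on an aromatic carbon. The measured steps bear on this only indirectly. a 7.6-fold higher number from compound 1 to compound 2 (0.88 log units; beyond the scatter) and a 7.6-fold higher number from compound 1 to compound 3 (0.88 log units; beyond the scatter) show that a phenyl bearing tert-butyl or trifluoromethyl in place of benzyl raised the number, and no change at the digits printed from compound 2 to compound 3 (within the scatter) shows that swapping trifluoromethyl for tert-butyl left it unchanged. None of these involves 2-methoxyphenoxy. For compound 4 the expected step is a 1.1-fold lower number from compound 3 to compound 4 (0.03 log units; within the scatter), nothing beyond the scatter. Compound 4 is therefore estimated to give 30000 nM in this assay, within a range of 10000 nM to 100000 nM.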

Compound 4, solubility: 14500 nM
Estimate against measurement, compound 4: 2.1-fold (0.32 log units) above; measured number inside the range.
By their numbers in this assay, from the lowest: compound 1; then compound 4; then compounds 2 and 3 (each within the scatter of the next).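

At this aromatic carbon of the shared core, the three earlier compounds showed only two levels in this assay, and exchanging tert-butyl for trifluoromethyl on the phenyl ring did not separate them. The 2-methoxyphenoxy group gives a third level: there is a 2.2-fold lower number from compound 3 to compound 4 (0.34 log units; beyond the scatter) and likewise a 2.2-fold lower number from compound 2 to compound 4 (0.34 log units; beyond the scatter) with this group in place, yet also a 3.5-fold higher number from compound 1 to compound 4 (0.54 log units; beyond the scatter) when it replaces benzyl, so compound 4 lies between compound 1 and the pair of compounds 2 and 3. The entering group brings two hydrogen-bond acceptors where 4-(trifluoromethyl)phenyl has none, but no measurement presented here accounts for this ordering.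

The change from 4-(trifluoromethyl)phenyl to 2-methoxyphenoxy alters the ring substituent and the connection to the core together, so the compounds shown cannot tell which of these sets the number for compound 4. From the compounds shown here alone, it also remains open how this position would respond to an unsubstituted phenoxy group, which would separate those two features, or to a different kind of group such as a morpholine or a carboxylic acid.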